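The source may report more compounds than this note shows. Statements on the series, on what has been measured and on what is new or still open speak of the compounds shown alone.

Measured in a functional assay for agonist activity at growth hormone secretagogue receptor type 1 (Homo sapiens), read by FLIPR; on this read-out higher numbers stand for an effect only at larger amounts of compound and lower numbers for an effect already at smaller amounts:

compound 1, `COc1cc2c(cc1N1C[C@@H](C)N[C@@H](C)C1)N(S(=O)(=O)CCc1ccccc1Cl)CC2`, gives 5.01 nM;
compound 2, `COc1cc2c(cc1N1CCN[C@@H](C)C1)N(S(=O)(=O)c1ccc(-c3ccccn3)s1)CC2`, gives 3.16 nM;
compound 3, `COc1cc2c(cc1N1CCN[C@H](C)C1)N(S(=O)(=O)c1ccc(-c3ccccn3)s1)CC2`, gives 3.98 nM.

The three numbers sit close together. Compound 3 differs from compound 2 only in configuration as drawn, and the step of a 1.3-fold higher number from compound 2 to compound 3 (0.10 log units; within the scatter) stays within the scatter, which is what the fact that compounds 2 and 3 differ only in the configuration as drawn would lead one to expect. Among the compounds with values here, compound 1, which carries a different sulfonyl group and a differently substituted saturated ring, gives a value that is likewise within the scatter of compound 3, though no single-point step connects them.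

Compound 4, `COc1cc2c(cc1N1C[C@H](C)NC(C)(C)C1)N(S(=O)(=O)c1ccc(-c3ccccn3)s1)CC2`, is the unmeasured compound. It is reached from compound 3 by the change (a group of 9 heavy atoms (7 carbon, 2 nitrogen; one six-membered non-aromatic ring with 2 hetero atoms) in place of a group of 7 heavy atoms (5 carbon, 2 nitrogen; one six-membered non-aromatic ring with 2 hetero atoms), on an aromatic carbon). Within the data shown here, no measured step covers this exact exchange; the only step at hand, from compound 2 to compound 3, alters the saturated ring at one stereocentre and moves the number by a margin within the scatter. On that basis compound 4 is expected to stay near compound 3, with a step of a 1.3-fold higher number from compound 3 to compound 4 (0.10 log units; within the scatter) that is not expected to exceed the scatter. The estimate for compound 4 in this assay is 5 nM, within 1.6 nM to 16 nM.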

Compound 4, half-maximal effective concentration: 0.794 nM
Compound 4: middle estimate off by 6.3-fold (0.80 log units), on the high side; the measured number lies below the stated range.
By their numbers in this assay, from the lowest: compound 4; then compounds 2, 3 and 1 (each within the scatter of the next).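

In this assay, the group on the aromatic carbon ortho to a methoxy group proves able to move the number: putting the group of 9 heavy atoms in place of 3-methylpiperazin-1-yl gives a 5.0-fold lower number from compound 3 to compound 4 (0.70 log units; beyond the scatter), and starting from the other configuration it gives a 4.0-fold lower number from compound 2 to compound 4 (0.60 log units; beyond the scatter). Both steps lie beyond the scatter, whereas a 1.3-fold higher number from compound 2 to compound 3 (0.10 log units; within the scatter) did not, so this exchange shows a response at the position that a change of configuration alone had not shown. Nothing available gives a cause for this response.

Within the data shown here, whether the same exchange has a like effect with a different sulfonyl group, such as the one in compound 1, stays open. Also open, going by these compounds, is what a morpholine ring or an open-chain amine would give at this position.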